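Para substituent swap on the aryl ring of compound 2

The compounds below may be only part of what the source reports. "The series", "measured", "known", "first", "only" and "open" are said of these compounds alone.

The series is followed in an assay on isolated protein for binding affinity to melanin-concentrating hormone receptor 1 (Homo sapiens); a higher number here means a weaker inhibitor, a lower number a stronger inhibitor. Among the compounds with values here, compound 2, `Cc1ccc(-c2cc3ncn([C@H]4CCN(C(=O)N(C)[C@H]5CCN(C)C5)C4)c(=O)c3s2)cc1`, gives 15 nM in this assay, the higher of the two numbers known so far. Compound 1, `CN(C(=O)N1CC[C@H](n2cnc3cc(-c4ccc(Cl)cc4)sc3c2=O)C1)[C@H]1CCN(Cc2ccoc2)C1`, gives 4 nM in this assay, a gap that lies beyond the usual scatter. Compound 3, `COc1ccc(-c2cc3ncn([C@H]4CCN(C(=O)N(C)[C@H]5CCN(C)C5)C4)c(=O)c3s2)cc1`, differs from compound 2 by methoxy in place of methyl on an aromatic carbon. Within the data shown here, no measured pair shows this change, so no step beyond the scatter is expected in either direction. In this assay compound 3 is estimated at 12 nM, between 5 nM and 30 nM. The expected step is a 1.3-fold lower number from compound 2 to compound 3 (0.10 log units; within the scatter), within the scatter.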

Compound 3, inhibition constant: 21 nM
For compound 3 the middle estimate is 1.8-fold (0.24 log units) below the measured one; the range from low to high includes it.
By their numbers in this assay, from the lowest: compound 1; then compounds 2 and 3 (each within the scatter of the next).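

In this assay, within the data shown here, the swap gives a 1.4-fold higher number from compound 2 to compound 3 (0.15 log units; within the scatter) and so gives the first direct reading at this place, on an aromatic carbon para to a large group. The 4-methylphenyl and 4-methoxyphenyl compounds cannot be told apart here, so the added oxygen of methoxy brings no step beyond the scatter. Nothing on hand explains this result.

Still open, on these data alone, is whether a nitrile, a carboxylic acid or an amine at this same place on compound 2 would give a step beyond the scatter, and in which direction.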